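Ethynyl in place of 4-methoxyphenyl: working notes on the series

This account rests on a few compounds, and the source may have more. Where it says the series, first, only, none or still open, it means among the compounds named here.

All values come from a functional assay on KYSE-70 cells for antiproliferative activity against KYSE-70 cell line (Homo sapiens), read by MTT assay, with a stated time of 72 h; a lower number here means a stronger inhibitor, a higher number a weaker inhibitor. Compound 1 `CC(C)(C)c1ccc(NC(=O)c2cc(=O)[nH]c3cc(Br)ccc23)cc1` returns only a limit of the assay, > 20000 nM. Compound 2 `O=C(Nc1cc(F)cc(F)c1)c1cc(=O)[nH]c2cc(Cl)ccc12` gives a number, 9000 nM. Compound 3 `COc1ccc(-c2ccc3c(C(=O)Nc4cccc(F)c4)cc(=O)[nH]c3c2)cc1` again returns only a limit, > 20000 nM. Compound 3 thus stands at the limit of > 20000 nM in this assay, at which 2 of the 3 values shown sit, with no number of its own, so its distance to compound 2 cannot be read.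

Compound 4 `C#Cc1ccc2c(C(=O)Nc3cccc(F)c3)cc(=O)[nH]c2c1` differs from compound 3 in one place: ethynyl in place of 4-methoxyphenyl on an aromatic carbon. For the measured compounds named here, compound 2, the one member with a number, carries a small substituent on its core and gives 9000 nM, which is the only hint that a smaller group at this ring may bring a value back into the measurable range. The step expected is an at least 1.6-fold lower number from compound 3 to compound 4 (0.22 log units; that floor lies within the scatter), a gain beyond the scatter, though the limit on compound 3 leaves its size loosely defined. Compound 4 is estimated at 12000 nM, within 4000 nM to 35000 nM, with a fair chance that only a limit is reported again.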

Compound 4, half-maximal inhibitory concentration: 9500 nM
Compound 4: middle estimate off by 1.3-fold (0.10 log units), on the high side, and the stated range covers the measured number.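

In this assay, for the compounds shown here, replacing 4-methoxyphenyl with ethynyl on this aromatic carbon gives an at least 2.1-fold lower number from compound 3 to compound 4 (0.32 log units; beyond the scatter), the first step that can be read. Compound 4 gives 9500 nM, so a substituent at this position is compatible with a measured number, and the change that achieves this swaps 8 heavy atoms and a six-membered aromatic ring for 2 heavy atoms and no ring. The size of the step remains a floor, since compound 3 has only a limit of the assay and no number: the limit of > 20000 nM in this assay, at which 2 of the 4 values shown sit.

This single pair cannot separate the loss of the ring from any contribution of the triple bond itself. Going by these compounds, how a small amine, a nitrile or a longer alkyne chain on the same carbon would read remains open.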